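A few compounds are considered here, and "the series" means these few. Any claim that something is new, unique, unknown or untested is made for them only; others in the source may bear on it.

Measured in a functional assay on cells (Endothelial cell, Bos taurus) for antiproliferative activity; on this read-out higher numbers stand for weaker inhibition and lower numbers for stronger inhibition:

- compound 1 `COc1cc(/C(F)=C/c2cc(O)c3ccsc3c2)cc(OC)c1OC`: 390 nM
- compound 2 `COc1ccc(/C=C(\F)c2cc(OC)c(OC)c(OC)c2)cc1N`: 86000 nM
- compound 3 `COc1cc(/C(F)=C/c2cc(O)c3ccoc3c2)cc(OC)c1OC`: > 1000 nM (a limit)

Only two of these three results are actual numbers, and compound 1 holds the lower of them at 390 nM. Compound 2 gives 86000 nM, a much higher number and well beyond the scatter of repeated measurements. Compound 3 is reported only as a limit, > 1000 nM.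

The next compound to be tested is compound 4 `COc1cc(/C(F)=C\c2cc(O)c3ccsc3c2)cc(OC)c1OC`. Its difference from compound 1 is the two compounds have the same atoms and bonds and differ only in configuration as drawn: 1 of 1 stereo elements differ; a double bond is drawn Z in compound 1 and E in compound 4. The two compounds have the same atoms and bonds, and a double bond is drawn Z in compound 1 and E in compound 4.

Among the measured compounds shown here, all three measured compounds carry this double bond drawn Z, so no measured pair shows what the reversal does in this assay. The expectation is therefore uncertain, but it leans towards stronger inhibition, by a step beyond the scatter, starting from the 390 nM of compound 1. The expected change is a 13-fold lower number from compound 1 to compound 4 (1.11 log units; beyond the scatter). The estimate for compound 4 is 30 nM, with an expected range from 3 nM to 400 nM.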

Compound 4, half-maximal inhibitory concentration: 23 nM
For compound 4 the middle estimate is 1.3-fold (0.12 log units) above the measured one; the measured number falls inside the stated range.
By their numbers in this assay, from the lowest: compound 4; then compound 1; then compound 2.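

In this assay, reversing the double bond from Z to E, with nothing else altered, gives a 17-fold lower number from compound 1 to compound 4 (1.23 log units; beyond the scatter), a large step. The earlier compounds shown here all carry this double bond drawn Z, so they gave no sign that its configuration matters, and the differences among them could not speak to this change. Compound 4 shows that the configuration at this one position is enough to move the read-out well beyond the scatter, and the step can be assigned to the reversal alone because no other part of the structure changes: the fact that compounds 1 and 4 differ only in the configuration as drawn

The value of compound 3, > 1000 nM, is a limit, and this compound, like compound 2, is shown only with the double bond drawn Z, so it remains open whether the same reversal would give a step of similar size on their structures. Also open, going by these compounds, is how compound 4 would respond if the hydroxyl group on its core gave way to a carboxylic acid, or if the fluorine on its double bond gave way to a nitrile.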